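Swapping a Phenyl for a Heptyl Chain

This account rests on a few compounds, and the source may have more. Where it says the series, first, only, none or still open, it means among the compounds named here.

Within the data shown here, of the two numbers measured so far in a functional assay on PC-3 cells (Homo sapiens) for cytotoxicity, read by MTT assay, with a stated time of 48 h (on this read-out higher numbers stand for weaker inhibition and lower numbers for stronger inhibition), compound 1 `[O-][n+]1nc(NCc2ccccc2)[n+]([O-])c2ccccc21` gives 10700 nM. Compound 2 `O=[N+]([O-])c1ccc(CNc2n[n+]([O-])c3ccccc3[n+]2[O-])cc1` gives 7400 nM in this assay. That pair shows a 1.4-fold lower number from compound 1 to compound 2 (0.16 log units; within the scatter). Compound 3 `CCCCCCCCNc1n[n+]([O-])c2ccccc2[n+]1[O-]` differs from compound 1 by heptyl in place of phenyl on a saturated chain carbon bound to a nitrogen on an aromatic ring. Among the measured compounds shown here, no measured step touches this change; the only known step concerns a nitro group and stays within the scatter, so nothing here supports a shift beyond the scatter in this assay. Compound 3 is therefore estimated at 9000 nM, expected to fall between 2500 nM and 35000 nM. The expected step is a 1.2-fold lower number from compound 1 to compound 3 (0.08 log units; within the scatter).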

Compound 3, half-maximal inhibitory concentration: 18200 nM
Beside the measured number, compound 3's estimate is 2.0-fold (0.31 log units) below it, and the stated range covers the measured number.
By their numbers in this assay, from the lowest: compounds 2, 1 and 3 (each within the scatter of the next, the first and the last beyond it).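

In this assay the position on a saturated chain carbon bound to a nitrogen on an aromatic ring shows a 1.7-fold higher number from compound 1 to compound 3 (0.23 log units; within the scatter) for heptyl in place of phenyl. So at this position, an open chain with no ring can stand where the phenyl stood without a step beyond the scatter, which the nitro step could not show. No evidence at hand gives a reason for this result.

From the compounds shown here alone, whether a shorter chain such as butyl would also stay within the scatter remains open. So does the effect of an amine or a carboxylic acid at the end of the chain.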